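A few compounds are considered here, and "the series" means these few. Any claim that something is new, unique, unknown or untested is made for them only; others in the source may bear on it.

Three compounds have been measured in a functional assay on the whole organism (strain Wistar) with Rattus norvegicus as the target, with a stated time of 15 days, at a dose of 10 mg/kg by the oral route; on this read-out lower numbers stand for a weaker effect and higher numbers for a stronger effect at the one dose given:

Compound 1 `O=C1NC(=O)/C(=C/c2ccc(OCCSc3nnc(-c4ccc(Cl)cc4)[nH]3)cc2)S1` gives 24.6%.
Compound 2 `O=C1NC(=O)/C(=C/c2ccc(OCCSc3nnc(-c4ccccc4)o3)cc2)S1` gives 22.2%.
Compound 3 `O=C1NC(=O)/C(=C/c2ccc(OCCSc3nnc(Cc4ccccc4)o3)cc2)S1` gives 20.5%.

On these numbers compound 3 stands lowest of the three, yet all three lie within the usual scatter of one another, so no ranking among them can be drawn. Compound 4 `O=C1NC(=O)/C(=C/c2ccc(OCCSc3nnc(-c4ccncc4)o3)cc2)S1` is not yet measured in this assay. It differs from compound 3 in one place: pyridin-4-yl in place of benzyl on an aromatic carbon. Going by the values given here, the only measured step that touches this position is a number 1.7 percentage points lower from compound 2 to compound 3 (within the scatter), and it stayed within the scatter. Among the compounds with values here, no measured pair shows phenyl against pyridin-4-yl, so that part of the change is without precedent here. Within the data shown here, since the one comparable step was small, compound 4 is expected to give a number close to that of compound 3, with a step of a number 0.5 percentage points higher from compound 3 to compound 4 (within the scatter) that is not expected to exceed the scatter. Compound 4 is therefore estimated at 21%, with a range from 12% to 31%.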

Compound 4, a percentage reported as activity, at one dose (the size of the read-out at that dose, not a potency): 42.2%
Compound 4: middle estimate off by 21.2 percentage points, on the low side, outside the stated range (above it).
By their numbers in this assay, from the lowest: compounds 3, 2 and 1 (each within the scatter of the next); then compound 4.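

In this assay, this position on the five-membered aromatic ring proves responsive, although phenyl and benzyl had stayed within the scatter of each other there. Pyridin-4-yl in place of benzyl gives a number 21.7 percentage points higher from compound 3 to compound 4 (beyond the scatter), and pyridin-4-yl in place of phenyl gives a number 20 percentage points higher from compound 2 to compound 4 (beyond the scatter). The second step keeps a six-membered aromatic ring on the same carbon and exchanges one ring carbon for a ring nitrogen, so an aromatic ring alone does not bring the higher number. Nothing in the data accounts for this rise.

Whether the location of the ring nitrogen matters stays open, as pyridin-3-yl and pyridin-2-yl do not appear among these compounds. Also open, from the compounds shown here alone, is whether a pyrimidine ring, or a phenyl ring carrying an amine or a carboxylic acid, would give a similar number at this position.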